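Swapping a methyl for a methoxycarbonyl on the phenyl ring

The source may hold more compounds than are shown below. What is called first, only, known or untested is meant among the compounds shown, and "the series" means these compounds.

Of the compounds shown here, two share a core and have been tested in a functional assay on the whole organism (strain Wistar) for inhibition, with Rattus norvegicus as the target, read by paw edema, with stated times of 1 h and 4 h, at a dose of 70 mg/kg by the oral route; a lower number here means less inhibition, a higher number more inhibition at the dose given (going by the name of the read-out). Compound 1 `Clc1ccc2nc(Nc3nnc(-c4ccccc4)o3)sc2c1` carries a plain phenyl ring, and in this assay compound 1 gives 88.3%. Compound 2 `Cc1ccccc1-c1nnc(Nc2nc3ccc(Cl)cc3s2)o1` carries a methyl on that ring, and in this assay compound 2 gives 37.7%. For the measured compounds named here, the single measured step, a number 50.6 percentage points lower from compound 1 to compound 2 (beyond the scatter), is large. Compound 2 therefore stands lowest of the two numbers, with compound 1 well above it.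

Compound 3 `COC(=O)c1ccccc1-c1nnc(Nc2nc3ccc(Cl)cc3s2)o1` is the next member. It differs from compound 2 as follows: methoxycarbonyl in place of methyl on an aromatic carbon. The group sits on an aromatic carbon of a six-membered aromatic ring of carbon only, ortho to a large group. Going by the values given here, no measured step covers a methoxycarbonyl at this place; the only step at hand shows that placing a methyl there lowered the number sharply. With nothing pointing back up, a value near compound 2 is expected, and a further fall is possible. The expected step is a number 4.7 percentage points lower from compound 2 to compound 3 (within the scatter). For compound 3 the estimate in this assay is 33%, within 12% to 58%.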

Compound 3, a percentage reported as inhibition, in the whole organism at one dose (the size of the read-out at that dose, not a potency): 50.8%
For compound 3 the middle estimate is 17.8 percentage points below the measured one, within the range that was stated.
By their numbers in this assay, from the lowest: compound 2; then compound 3; then compound 1.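

In this assay, this position on the phenyl ring does not respond to every group in the same way: going from methyl to methoxycarbonyl gives a number 13.1 percentage points higher from compound 2 to compound 3 (beyond the scatter), a modest step that wins back part of the loss seen with methyl. The plain ring remains out of reach, however, as methoxycarbonyl in place of hydrogen gives a number 37.5 percentage points lower from compound 1 to compound 3 (beyond the scatter), a large step, so among these three compounds both groups at this place go with a lower number than hydrogen. No measurement of any property of these groups is available to account for the gap between them.

Methoxycarbonyl differs from methyl in more than one way, bringing more heavy atoms and two hydrogen-bond acceptors at once, and the compounds shown do not separate these features. A carboxylic acid or an amine on this same aromatic carbon would be a useful comparison, showing whether the number follows the acceptors, the size of the group or something else entirely.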